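Aryl ether variation on a prostacyclin synthase inhibitor series

The source may report more compounds than this note shows. Statements on the series, on what has been measured and on what is new or still open speak of the compounds shown alone.

Measured compounds and their values:
compound 1 `N#Cc1ccc(C2OCC(C/C=C\CCC(=O)O)C(c3cccnc3)O2)cc1` gives > 100000 nM (a limit of the assay);
compound 2 `O=C(O)CC/C=C\CC1COC(c2ccc(Cl)cc2Cl)OC1c1cccnc1` gives 2500 nM;
compound 3 `Cc1ccc(OC(C)(C)C2OCC(C/C=C\CCC(=O)O)C(c3cccnc3)O2)cc1` gives 25000 nM.

These were recorded in an assay for inhibition of prostacyclin synthase (Homo sapiens), using microsomes; on this read-out higher numbers stand for weaker inhibition and lower numbers for stronger inhibition. Of the two numbers on hand, compound 3 stands highest, with compound 2 nearest at a lower value. Compound 1 is known only as a limit in this assay. For the measured compounds named here, the one step between compounds that differ in a single place, an at least 40-fold lower number from compound 1 to compound 2 (1.60 log units; beyond the scatter), concerns the aryl group attached directly to a saturated ring carbon, a different position from the one considered here; its size is marked by the limit of > 100000 nM in this assay, at which 1 of the 3 values shown sits, on the side of compound 1.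

Compound 4 `COc1ccc(OC(C)(C)C2OCC(C/C=C\CCC(=O)O)C(c3cccnc3)O2)c([N+](=O)[O-])c1` is not yet measured. It differs from compound 3 by 4-methoxy-2-nitrophenyl in place of 4-methylphenyl on an oxygen on a saturated carbon. Going by the values given here, no measured step touches this oxygen-borne aryl group, so the single available step gives no direct guide to its size or direction.

For compound 4 the expectation in this assay is therefore a number close to compound 3, with the step of a 1.3-fold lower number from compound 3 to compound 4 (0.10 log units; within the scatter) estimated to remain moderate. The estimate for compound 4 is 20000 nM, in a range from 4000 nM to 90000 nM.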

Compound 4, half-maximal inhibitory concentration: 23000 nM
For compound 4 the middle estimate is 1.2-fold (0.06 log units) below the measured one, and the stated range covers the measured number.
By their numbers in this assay, from the lowest: compound 2; then compounds 4 and 3 (each within the scatter of the next). At a limit, above all of these: compound 1.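

In this assay the aryl group on an oxygen on a saturated carbon now has a measured step of its own (a 1.1-fold lower number from compound 3 to compound 4 (0.04 log units; within the scatter)), whereas the earlier step concerned only the aryl group on a saturated ring carbon. The two numbers lie within the scatter of each other, even though the entering 4-methoxy-2-nitrophenyl has 11 heavy atoms and 3 hydrogen-bond acceptors against 7 heavy atoms and 0 hydrogen-bond acceptors for the leaving 4-methylphenyl, so in this one pair the read-out does not follow the size of the substitution. Nothing on hand gives a cause for this outcome.

The methoxy and nitro groups enter together in this pair, so their separate contributions cannot be read, and either one might count for more alone than the pair shows. As far as these compounds go, whether an aryl group carrying an amine or a carboxylic acid at this place, or a longer chain between this oxygen and the shared core, would stay at the same level remains open.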